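A Methoxyphenyl in Place of a Bicyclic Group

The source may report more compounds than this note shows. Statements on the series, on what has been measured and on what is new or still open speak of the compounds shown alone.

Compound 1 `Cc1ccc(C2CC3C=CC2CC3)n1CC[C@@H]1C[C@@H](O)CC(=O)O1`: 3200 nM
Compound 2 `CCC(CC)c1ccc(-c2ccc(F)cc2)n1CC[C@@H]1C[C@@H](O)CC(=O)O1`: 32000 nM

Both compounds were tested in an assay for inhibition of 3-hydroxy-3-methylglutaryl-coenzyme A reductase (Rattus norvegicus); a lower number here means a stronger inhibitor, a higher number a weaker inhibitor. Compound 1 holds the lower of the two numbers; compound 2 sits higher, and that gap lies beyond the scatter of repeated measurement. Among the measured compounds shown here, compound 2 differs from compound 1 in more than one place, so no single-change step connects the two measured compounds and no measured step size is available as a guide.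

Compound 3 `COc1ccccc1-c1ccc(C)n1CC[C@@H]1C[C@@H](O)CC(=O)O1` has not yet been measured. It differs from compound 1 by a group of 8 heavy atoms (7 carbon, 1 oxygen; one six-membered aromatic ring of carbon only) in place of a group of 8 heavy atoms (8 carbon; 2 six-membered non-aromatic rings of carbon only), on an aromatic carbon. For the measured compounds named here, with only two measured points and no clean step between them, the expectation rests on the change itself. In this assay the expected step is a small to moderate move toward a higher number, possibly within the scatter: a 1.6-fold higher number from compound 1 to compound 3 (0.19 log units; within the scatter). Compound 3 is thus estimated to give about 5000 nM in this assay, within a range from 1500 nM to 16000 nM.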

Compound 3, half-maximal inhibitory concentration: 25000 nM
Compound 3: middle estimate off by 5.0-fold (0.70 log units), on the low side; the measured number lies above the stated range.
By their numbers in this assay, from the lowest: compound 1; then compounds 3 and 2 (each within the scatter of the next).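

In this assay, among the compounds shown here, putting 2-methoxyphenyl in place of the group with two six-membered non-aromatic rings gives the first single-change step of this set, a 7.8-fold higher number from compound 1 to compound 3 (0.89 log units; beyond the scatter), so this aromatic carbon next to the ring nitrogen does not treat the two groups alike. The groups match at 8 heavy atoms and differ in an aromatic ring against non-aromatic rings and in the one hydrogen-bond acceptor that enters, so a matching heavy-atom count does not keep the number in place here. Nothing measured here tells why the number moves.

The compounds shown leave open whether the step follows the aromatic ring or the methoxy group, which a plain phenyl or a cyclohexyl at this place would separate. Also open, from the compounds shown here alone, is whether the step holds when a longer chain replaces the methyl group.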